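Swapping the Nitro-Bearing Ring for a Dichlorophenyl

The source may hold more compounds than are shown below. What is called first, only, known or untested is meant among the compounds shown, and "the series" means these compounds.

Of the compounds shown here, two have been measured so far, both built on the same core, a dienone chain carrying an aromatic ring at each end. Compound 1 `O=C(/C=C/c1ccc(Cl)c([N+](=O)[O-])c1)/C=C/c1ccccc1Oc1ncnc2ccc(Cl)cc12` gives 9760 nM in a functional assay on PC-3 cells (Homo sapiens) for inhibition, read by MTT assay, with a stated time of 72 h; on this read-out higher numbers stand for weaker inhibition and lower numbers for stronger inhibition. Compound 2 `O=C(/C=C/c1ccc(Oc2ncnc3ccc(Cl)cc23)cc1)/C=C/c1cccc(Cl)c1Cl` gives 10200 nM in this assay. Compound 1 holds the lower of the two numbers, but the gap to compound 2 lies within the usual scatter, so the two are indistinguishable on this read-out.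

Compound 3 `O=C(/C=C/c1ccccc1Oc1ncnc2ccc(Cl)cc12)/C=C/c1cccc(Cl)c1Cl` has not yet been measured. It differs from compound 1 in one place: 2,3-dichlorophenyl in place of 4-chloro-3-nitrophenyl on a double-bonded chain carbon bound to a double-bonded chain carbon. The entering group is the same one found at the corresponding end of compound 2, while the other end of compound 3 matches compound 1. Among the compounds with values here, no measured pair shows this exact change on its own. Since compound 1 and compound 2 sit within the scatter of each other, the step from compound 1 to compound 3 is expected to be small and in no particular direction, as a 1.1-fold lower number from compound 1 to compound 3 (0.04 log units; within the scatter). Compound 3 is therefore expected to give about 9000 nM, within 3000 nM to 27000 nM.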

Compound 3, half-maximal inhibitory concentration: 8350 nM
Compound 3: middle estimate off by 1.1-fold (0.03 log units), on the high side; the measured number falls inside the stated range.
By their numbers in this assay, from the lowest: compounds 3, 1 and 2 (each within the scatter of the next).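

Within the data shown here, putting 2,3-dichlorophenyl in place of 4-chloro-3-nitrophenyl on a double-bonded chain carbon bound to a double-bonded chain carbon gives, in this assay, a 1.2-fold lower number from compound 1 to compound 3 (0.07 log units; within the scatter), which is the first direct reading of this change on its own. The nitro group and its 2 hydrogen-bond acceptors leave, a second chlorine enters with 0 hydrogen-bond acceptors, and the read-out still cannot tell compound 1 and compound 3 apart, so at this position the two rings are interchangeable in this assay. Nothing available explains why the read-out stays level across this swap.

Going by these compounds, both rings compared here are chlorine-bearing phenyl groups, so it remains open whether a very different group at this place, such as an amine, a carboxylic acid or an unsubstituted phenyl ring, would move the number beyond the scatter. On these data alone, it is also open whether the same equivalence of the two rings would hold on a different core or in a different kind of assay.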